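Halogen additions in a sulfonyl-linked anilinoquinazoline series

The compounds below may be only part of what the source reports. "The series", "measured", "known", "first", "only" and "open" are said of these compounds alone.

Compound 1 `O=S(=O)(/C=C/c1ccc(Cl)cc1Cl)Cc1ccc(Nc2ncnc3ccccc23)cc1` was tested in a functional assay on UACC-62 cells (Homo sapiens) (on this read-out higher numbers stand for weaker inhibition of growth and lower numbers for stronger inhibition of growth), where compound 1 gives 2000 nM. Compound 3 `O=S(=O)(/C=C/c1ccc(Cl)cc1Cl)Cc1ccc(Nc2ncnc3ccc(Br)cc23)cc1` gives 2000 nM in this assay; the step of no change at the digits printed from compound 1 to compound 3 (within the scatter) is bromo in place of hydrogen on an aromatic carbon. Compound 2 `O=S(=O)(/C=C/c1ccc(Cl)cc1)Cc1ccc(Nc2ncnc3ccc(Br)cc23)cc1` gives 15000 nM in this assay, and the change chloro in place of hydrogen on an aromatic carbon brought a 7.5-fold lower number from compound 2 to compound 3 (0.88 log units; beyond the scatter). Compound 4 `O=S(=O)(/C=C/c1ccc(Cl)cc1Cl)Cc1ccc(Nc2ncnc3cc(Cl)ccc23)cc1` differs from compound 1 by chloro in place of hydrogen on an aromatic carbon. This is the same kind of change as from compound 2 to compound 3, not the same: there the chloro entered ortho to a large group and meta to a chloro group, whereas here it sits in a fused or bridged system of two rings, meta and para to a fused ring. The difference between the cores of compound 1 and compound 2 is not broken down here. Because no change at the digits printed from compound 1 to compound 3 (within the scatter) showed a halogen on that aromatic carbon leaving the number unchanged, the expected step is no change at the digits printed from compound 1 to compound 4 (within the scatter). Compound 4 is therefore estimated at 2000 nM, expected between 800 nM and 5000 nM.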

Compound 4, concentration for 50% growth inhibition: 32000 nM
Compound 4: the middle estimate sits 16-fold (1.20 log units) below what was measured; measured number outside the range, above it.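

In this assay, chloro in place of hydrogen on an aromatic carbon of the fused system of two rings gave a 16-fold higher number from compound 1 to compound 4 (1.20 log units; beyond the scatter). Set beside the earlier step, the same change ran in opposite directions: the same change on two cores in this assay, a 7.5-fold lower number (0.88 log units; beyond the scatter) from compound 2 to compound 3 and a 16-fold higher number (1.20 log units; beyond the scatter) from compound 1 to compound 4, 120-fold (2.08 log units) apart, beyond the scatter of two such steps. Among these compounds, this shows that the result of this change on one core cannot simply be carried to another, but it does not show whether the core or the place of the chloro accounts for the gap, since the two chloro groups sit on different rings and only two steps are available.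

From the compounds shown here alone, it remains open how a fluoro, a methoxy or an amine on the same aromatic carbon of compound 1 would compare with the chloro of compound 4.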